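Swapping a Cyclic Carbamate for a Cyclic Sulfonamide

The compounds below may be only part of what the source reports. "The series", "measured", "known", "first", "only" and "open" are said of these compounds alone.

Among the measured compounds shown here, compound 1 `Cc1nc(N2CCC(N3CCOC3=O)CC2)nc2ccc(NC(=O)/C=C/c3ccc(OC(F)(F)F)cc3)cc12` is the only member of this small set with a number in hand. In an ADME assay on microsomes from liver (Homo sapiens) for metabolic stability, with a stated time of 30 min (on this read-out higher numbers stand for a more stable compound and lower numbers for a less stable compound), compound 1 gives 85%, so a large share of the compound survives the incubation. Compound 2 `Cc1nc(NCCCNS(C)(=O)=O)nc2ccc(NC(=O)/C=C/c3ccc(OC(F)(F)F)cc3)cc12`, which carries an open chain in place of the saturated six-membered ring, has no number in hand: in this assay compound 2 gives "not determined" (no result reported), so it offers no point of comparison.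

Compound 3 `Cc1nc(N2CCC(N3CCCS3(=O)=O)CC2)nc2ccc(NC(=O)/C=C/c3ccc(OC(F)(F)F)cc3)cc12` has not yet been measured. It differs from compound 1 by a group of 7 heavy atoms (3 carbon, 1 nitrogen, 2 oxygen, 1 sulfur; one five-membered non-aromatic ring with 2 hetero atoms) in place of a group of 6 heavy atoms (3 carbon, 1 nitrogen, 2 oxygen; one five-membered non-aromatic ring with 2 hetero atoms), on a saturated ring carbon. For the measured compounds named here, no step between two measured compounds is available to calibrate this change. The expected step in this assay from compound 1 to compound 3 is a number 5 percentage points lower from compound 1 to compound 3 (within the scatter), essentially none beyond the scatter, with a slight lean downward. Compound 3 is therefore estimated at 80%, within a range from 60% to 95%.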

Compound 3, percent of the compound remaining: 85%
For compound 3 the middle estimate is 5 percentage points below the measured one; the measured number falls inside the stated range.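

Among the compounds shown here, at this saturated ring carbon, the 2-oxo-1,3-oxazolidin-3-yl group can be exchanged for the sulfur-bearing five-membered ring with no change at the digits printed from compound 1 to compound 3 (within the scatter) in this assay, and this is the first step in the set between two measured compounds. The exchange adds a sulfur atom and a second double bond outside aromatic rings, while the ring size, the counts of hydrogen-bond donors and acceptors and the absence of net charge stay the same, so this pair shows that the read-out can hold through that particular difference at this position. For the compounds shown here, nothing measured here accounts for this result, and the single pair offers no explanation for it.

From the compounds shown here alone, whether the read-out would also hold with a group of another kind on this ring carbon, such as a primary amine, a carboxylic acid or a longer chain ending in a methyl ether, remains open. Also open, going by these compounds, is how the read-out responds when the saturated six-membered ring itself gives way to an open chain like that of compound 2.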